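The source may hold more compounds than are shown below. What is called first, only, known or untested is meant among the compounds shown, and "the series" means these compounds.

Measured so far in a functional assay on SK-BR-3 cells (Homo sapiens) for cytotoxicity, read by MTT assay, with a stated time of 72 h; on this read-out lower numbers stand for stronger inhibition and higher numbers for weaker inhibition
compound 1 `N[C@H]1CC[C@H](Nc2c(C(=O)NCc3ccc(Oc4ccccc4)cc3)nc(Br)c3cccnc23)CC1` gives "not determined" (no result reported)
compound 2 `N[C@H]1CC[C@H](NC(=O)c2nc(Br)c3cccnc3c2NCc2ccc(F)cc2)CC1` gives 2800 nM
compound 3 `O=C(NCCCNc1c(C(=O)NCc2ccc(F)cc2)nc(Br)c2cccnc12)c1ccccc1` gives 1000 nM

Compound 1 has no number in this assay and so holds no place on this scale. Among the compounds with values here, compound 4 `N[C@H]1CC[C@H](Nc2c(C(=O)NCc3ccc(Cl)cc3)nc(Br)c3cccnc23)CC1` carries chloro in place of phenoxy on an aromatic carbon, para to a large group, a change counted as chloro in place of phenoxy on an aromatic carbon and seen in no measured pair. Without a value for compound 1, no step size can be read, and no step beyond the scatter is expected in either direction. Within the data shown here, the only guides are the values of compound 2 (2800 nM) and compound 3 (1000 nM). Compound 4 is expected at 1600 nM (estimated range 500 nM to 5000 nM).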

Compound 4, half-maximal inhibitory concentration: 2000 nM
The estimate for compound 4 lay 1.3-fold (0.10 log units) below the measured number, within the range that was stated.
By their numbers in this assay, from the lowest: compounds 3, 4 and 2 (each within the scatter of the next, the first and the last beyond it).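

In this assay no step can be read between compound 1 and compound 4. The compounds shown leave open how chloro in place of phenoxy would shift the value. No evidence bears on this result.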